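Phenyl to benzyl on two cores: cytotoxicity notes

The compounds below may be only part of what the source reports. "The series", "measured", "known", "first", "only" and "open" are said of these compounds alone.

Compound 1 `COc1cc2c(cc1C(C)OCc1ccccc1)C=CC(C)(C)O2` and compound 2 `COc1cc2c(cc1C(C)OCCc1ccccc1)C=CC(C)(C)O2` share one core; compound 3 `COc1cc2c(cc1C(C)NCCCc1ccccc1)CCC(C)(C)O2` and compound 4 `COc1cc2c(cc1C(C)NCCCCc1ccccc1)CCC(C)(C)O2` share another, and the difference between the two cores is not broken down here. In an ADME assay on L6 cells (Rattus norvegicus) for cytotoxicity (on this read-out higher numbers stand for weaker inhibition and lower numbers for stronger inhibition), compound 1 gives 43900 nM, and compound 2 gives 123000 nM. The change between them is benzyl in place of phenyl on a saturated chain carbon bound to an oxygen on a saturated carbon, and it made a 2.8-fold higher number from compound 1 to compound 2 (0.45 log units; beyond the scatter), so within this pair the benzyl compound is the weaker inhibitor. In this assay compound 3 gives 2630 nM, the lowest number of the three measured, with compound 1 and compound 2 both well above it. The change from compound 3 to compound 4 is benzyl in place of phenyl on a saturated chain carbon, three bonds along the chain from an amine nitrogen. This is the same kind of change as in the measured pair, but the place differs: there the saturated chain carbon was bound to an oxygen on a saturated carbon, here it is three bonds along the chain from an amine nitrogen. One measured step on a different core is a thin basis, so the expectation is held loose. The step is expected to be a 2.5-fold higher number from compound 3 to compound 4 (0.39 log units; beyond the scatter), in the same direction as the measured one. Compound 4 is estimated at 6500 nM, with an expected range from 2200 nM to 20000 nM.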

Compound 4, half-maximal inhibitory concentration: 5280 nM
Beside the measured number, compound 4's estimate is 1.2-fold (0.09 log units) above it, and the stated range covers the measured number.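

The new step in this assay is a 2.0-fold higher number from compound 3 to compound 4 (0.30 log units; within the scatter), so on its own it does not separate the pair. Set beside the step on the other core, the change shows no difference that can be read between the two cores: the same change on two cores in this assay, a 2.8-fold higher number (0.45 log units; beyond the scatter) from compound 1 to compound 2 and a 2.0-fold higher number (0.30 log units; within the scatter) from compound 3 to compound 4, 1.4-fold (0.14 log units) apart, within the scatter of two such steps This means the change can be carried across these two cores without a visible break, but it does not show a real shift on the core of compound 3, and two steps cannot establish a rule for other cores in the series.

Still open, from the compounds shown here alone, is whether a longer chain, or a phenyl ring bearing a fluorine or a carboxylic acid, would follow the same course on either core. Also open, going by these compounds, is how much of the gap between compound 3 and the oxygen-linked compounds belongs to the amine nitrogen and how much to the rest of the core, since those compounds differ in more than one place.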